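The source may hold more compounds than are shown below. What is called first, only, known or untested is meant among the compounds shown, and "the series" means these compounds.

Measured so far:
compound 1 `CN(C)c1ccc(/C=C(/SCc2ccc(Cl)cc2Cl)C(=O)c2ccc(Cl)cc2)cc1` gives 50000 nM in a functional assay on DU-145 cells (Homo sapiens) for inhibition, read by trypan blue exclusion, with a stated time of 96 h; on this read-out lower numbers stand for stronger inhibition of growth and higher numbers for weaker inhibition of growth;
compound 2 `CN(C)c1ccc(/C=C(/SCc2ccc(Cl)c(Cl)c2)C(=O)c2ccc(Cl)cc2)cc1` gives 50000 nM in this assay;
compound 3 `O=C(/C(=C\c1ccc(Oc2ccccc2)cc1)SCc1ccccc1Cl)c1ccc(Cl)cc1` gives 1000 nM in this assay.

Compound 3 stands lowest of the three numbers; compounds 1 and 2 both sit far higher, beyond the scatter. Among the compounds with values here, the one measured step, no change at the digits printed from compound 1 to compound 2 (within the scatter), does not touch the change now in question. Compound 4 `CN(C)c1ccc(/C=C(/SCc2ccccc2Cl)C(=O)c2ccc(Cl)cc2)cc1` differs from compound 3 in one place: dimethylamino in place of phenoxy on an aromatic carbon. Within the data shown here, no measured pair covers this change directly; what the data show is that both compounds carrying a dimethylamino group, compound 1 and compound 2, give weak numbers, while compound 3 with phenoxy gives the strong one. Compound 4 is therefore expected to lose potency sharply, with an expected step of a 30-fold higher number from compound 3 to compound 4 (1.48 log units; beyond the scatter). The estimate for compound 4 is 30000 nM, expected between 5000 nM and 60000 nM.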

Compound 4, concentration for 50% growth inhibition: > 100000 nM
Compound 4: only a limit was reported (the forecaster's own chance of this, stated with the estimate: 20%); at least 3.3-fold (0.52 log units) between middle value and limit.
By their numbers in this assay, from the lowest: compound 3; then compounds 1 and 2 (each within the scatter of the next). At a limit, above all of these: compound 4.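

Dimethylamino in place of phenoxy, on an aromatic carbon para to a large group, gives a direct measure of this change in this assay for the first time: an at least 100-fold higher number from compound 3 to compound 4 (2.00 log units; beyond the scatter) (large). For compound 4 the reported figure (> 100000 nM) is a limit. The steps among the dimethylamino compounds set no order, since both are floors: an at least 2.0-fold higher number from compound 2 to compound 4 (0.30 log units; that floor lies within the scatter) and an at least 2.0-fold higher number from compound 1 to compound 4 (0.30 log units; that floor lies within the scatter).

Going by these compounds, whether methoxy or a cyclic amine such as morpholine at this aromatic carbon would stay near compound 3 remains open. So does the effect of the chlorophenyl pattern with phenoxy present.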